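A Charged Chain Replaces the Ring in Compound 4

The source may hold more compounds than are shown below. What is called first, only, known or untested is meant among the compounds shown, and "the series" means these compounds.

Compound 3 `COc1ccccc1C1CC(C)=NN1C(=O)CN1CCC(OC)CC1` gives 27200 nM in a functional assay on PC-3 cells (Homo sapiens) for cytotoxicity, read by MTT assay, with a stated time of 48 h; a lower number here means a stronger inhibitor, a higher number a weaker inhibitor. Among the three measured compounds it holds the second highest number: compound 1 `CC1=NN(S(=O)(=O)c2ccc([N+](=O)[O-])cc2)C(c2cc(Br)cc(Br)c2O)C1` gives 50000 nM, a gap that lies within the scatter, while compound 2 `CC1=NN(C(=O)CN2CCN(C)CC2)C(c2ccccc2O)C1` gives 11800 nM, a gap beyond it. Compound 4 `CC[N+](C)(CC)CC(=O)N1N=C(C)CC1c1ccccc1OC` differs from compound 3 in one place: a group of 6 heavy atoms (5 carbon, 1 nitrogen; no ring) in place of a group of 8 heavy atoms (6 carbon, 1 nitrogen, 1 oxygen; one six-membered non-aromatic ring with 1 hetero atom), on a saturated chain carbon bound to a carbonyl carbon. Within the data shown here, no measured pair shows this change, so the expected step from compound 3 to compound 4, a 1.5-fold higher number from compound 3 to compound 4 (0.17 log units; within the scatter), is a modest shift toward a higher number, expected to sit close to the edge of the scatter. Compound 4 is estimated to give 40000 nM in this assay, with a range from 15000 nM to 100000 nM.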

Compound 4, half-maximal inhibitory concentration: 4170 nM
The estimate for compound 4 lay 9.6-fold (0.98 log units) above the measured number; the whole stated range lies above it.
By their numbers in this assay, from the lowest: compound 4; then compound 2; then compounds 3 and 1 (each within the scatter of the next).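

Among these compounds, the earlier compounds offered no pair differing in one place, so this is the first direct reading of this position, on a saturated chain carbon bound to a carbonyl carbon. In this assay, replacing the 4-methoxypiperidin-1-yl group with an open chain carrying a net charge of +1 gives a 6.5-fold lower number from compound 3 to compound 4 (0.81 log units; beyond the scatter), so a ring is not needed here for a low number. No measurement at hand explains this step. Going by these compounds, whether the charge or the loss of the ring matters remains open; a diethylamino group, lacking the methyl on the nitrogen, would help separate the two.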